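Compound 3 and a Nitro Group Replacing Methoxy

A few compounds are considered here, and "the series" means these few. Any claim that something is new, unique, unknown or untested is made for them only; others in the source may bear on it.

Of the compounds shown here, three sharing one core have been tested in an assay on membranes from brain for displacement of a labelled ligand from Sigma non-opioid intracellular receptor 1 (Cavia porcellus), read by scintillation counting, with a stated time of 120 min; a higher number here means a weaker inhibitor, a lower number a stronger inhibitor. Compound 1 `COC1Cc2cscc2C2(CCN(Cc3ccccc3)CC2)O1` gives 0.22 nM. Compound 2 `COC1Cc2c(csc2-c2ccccc2)C2(CCN(Cc3ccccc3)CC2)O1` gives 1 nM, and compound 3 `COc1ccc(-c2scc3c2CC(OC)OC32CCN(Cc3ccccc3)CC2)cc1` gives 2.2 nM. Compound 3 thus has the highest number of the three: the nearest step is a 2.2-fold higher number from compound 2 to compound 3 (0.34 log units; beyond the scatter), the furthest is a 10-fold higher number from compound 1 to compound 3 (1.00 log units; beyond the scatter). Compound 4 `COC1Cc2c(csc2-c2ccc([N+](=O)[O-])cc2)C2(CCN(Cc3ccccc3)CC2)O1` has not yet been measured; it differs from compound 3 by nitro in place of methoxy on an aromatic carbon. The step of a 2.2-fold higher number from compound 2 to compound 3 (0.34 log units; beyond the scatter) concerns the very group that now leaves, and it was modest; the steps of a 4.5-fold higher number from compound 1 to compound 2 (0.66 log units; beyond the scatter) and a 10-fold higher number from compound 1 to compound 3 (1.00 log units; beyond the scatter) show that adding groups at this part of the core raised the number only moderately. The step of a 1.4-fold higher number from compound 3 to compound 4 (0.13 log units; within the scatter) is therefore expected to be small. Compound 4 is expected to give 3 nM, with a range from 1 nM to 10 nM.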

Compound 4, inhibition constant: 1 nM
Estimate against measurement, compound 4: 3.0-fold (0.48 log units) above, and the stated range covers the measured number.
By their numbers in this assay, from the lowest: compound 1; then compounds 2 and 4 (each within the scatter of the next); then compound 3.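

In this assay, the swap at this position gives a 2.2-fold lower number from compound 3 to compound 4 (0.34 log units; beyond the scatter), while adding nitro to the plain phenyl gives no change at the digits printed from compound 2 to compound 4 (within the scatter), so a group here does not always raise the number as methoxy did. The phenyl ring still carries a cost with nitro in place, with a 4.5-fold higher number from compound 1 to compound 4 (0.66 log units; beyond the scatter). Nothing measured here explains why methoxy and nitro differ. From the compounds shown here alone, whether an amine or a carboxylic acid at this position would behave like methoxy or like nitro remains open. So does the effect of moving nitro elsewhere on the phenyl ring.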